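Compound 4: nitro exchanged for cyano, an expectation

The compounds below may be only part of what the source reports. "The series", "measured", "known", "first", "only" and "open" are said of these compounds alone.

Compound 1 `O=c1ccoc2cc(OCc3cn(Cc4ccccc4)nn3)ccc12`: > 100000 nM
Compound 2 `Cc1ccc(Cn2cc(COc3ccc4c(=O)ccoc4c3)nn2)cc1`: 50700 nM
Compound 3 `O=c1ccoc2cc(OCc3cn(Cc4cccc([N+](=O)[O-])c4)nn3)ccc12`: 9450 nM

In a functional assay on A549 cells (Homo sapiens) for cytotoxicity, read by MTT assay, with a stated time of 48 h (a higher number here means a weaker inhibitor, a lower number a stronger inhibitor), compound 1 reaches only a limit, > 100000 nM, the upper bound of the assay (the limit of > 100000 nM in this assay, at which 1 of the 3 values shown sits). Compound 2 gives 50700 nM and compound 3 gives 9450 nM, so compound 3 has the lowest number shown, with compound 2 nearest at a 5.4-fold lower number from compound 2 to compound 3 (0.73 log units; beyond the scatter). The step of an at least 10-fold lower number from compound 1 to compound 3 (1.02 log units; beyond the scatter) is large, whereas an at least 1.9-fold lower number from compound 1 to compound 2 (0.29 log units; that floor lies within the scatter) stays within the scatter. Compound 4 `N#Cc1cccc(Cn2cc(COc3ccc4c(=O)ccoc4c3)nn2)c1` arises from compound 3 by cyano in place of nitro on an aromatic carbon. Going by the values given here, no measured step exchanges these two groups, so the size of the change is open. Because an at least 10-fold lower number from compound 1 to compound 3 (1.02 log units; beyond the scatter) shows the whole gain came with the nitro group, compound 4 is expected to keep only part of it. The expected step is a 2.1-fold higher number from compound 3 to compound 4 (0.33 log units; beyond the scatter). Compound 4 is thus estimated at 20000 nM, between 6000 nM and 70000 nM.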

Compound 4, half-maximal inhibitory concentration: 14300 nM
The estimate for compound 4 lay 1.4-fold (0.15 log units) above the measured number, and the stated range covers the measured number.
By their numbers in this assay, from the lowest: compounds 3 and 4 (each within the scatter of the next); then compound 2. At a limit, above all of these: compound 1.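

In this assay, the drop in the number at this aromatic carbon does not depend on nitro alone: cyano in place of nitro gives a 1.5-fold higher number from compound 3 to compound 4 (0.18 log units; within the scatter), and cyano in place of hydrogen gives an at least 6.9-fold lower number from compound 1 to compound 4 (0.84 log units; beyond the scatter). That second step is only a floor, since compound 1 stands at a limit: the limit of > 100000 nM in this assay, at which 1 of the 4 values shown sits. The 3-cyanophenyl group also stays apart from 4-methylphenyl, with a 3.5-fold lower number from compound 2 to compound 4 (0.55 log units; beyond the scatter).

Going by these compounds, whether an amine or a carboxylic acid on this same carbon would hold the number down stays open. So does the effect of cyano or nitro alone on any other carbon of this ring.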